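The source may hold more compounds than are shown below. What is called first, only, known or untested is meant among the compounds shown, and "the series" means these compounds.

Compound 1 `COc1ccc(NC(=O)NCCNS(=O)(=O)c2sccc2-c2ccc(C)cc2Oc2ccc(O)c(O)c2)cc1` gives 8200 nM
Compound 2 `COc1ccc(NC(=S)NCCNS(=O)(=O)c2sccc2-c2ccc(C)cc2Oc2ccc(O)c(O)c2)cc1` gives 8300 nM

In a functional assay on RS4-11 cells (Homo sapiens) for inhibition, read by CCK-8 assay, with a stated time of 48 h (a higher number here means a weaker inhibitor, a lower number a stronger inhibitor), compound 2 gives 8300 nM and stands level with compound 1 within the scatter. Compound 3 `Cc1ccc(-c2ccsc2S(=O)(=O)NCCNC(=O)Nc2ccc([N+](=O)[O-])cc2)c(Oc2ccc(O)c(O)c2)c1` carries a new group on the amine nitrogen, as a group of 12 heavy atoms (7 carbon, 2 nitrogen, 3 oxygen; one six-membered aromatic ring of carbon only) in place of a group of 11 heavy atoms (8 carbon, 1 nitrogen, 1 oxygen, 1 sulfur; one six-membered aromatic ring of carbon only), on an amine nitrogen sets out. For the measured compounds named here, the only measured step, a 1.0-fold higher number from compound 1 to compound 2 (0.01 log units; within the scatter) (within the scatter), concerns the same place, but no measured compound carries the (4-nitrophenyl)carbamoyl group. No step beyond the scatter is therefore expected in this assay and this expectation remains loose. The estimated step is a 1.0-fold lower number from compound 2 to compound 3 (0.02 log units; within the scatter) on this evidence. Compound 3 is expected at 8000 nM (range 3000 nM to 20000 nM)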

Compound 3, half-maximal inhibitory concentration: 7700 nM
Estimate against measurement, compound 3: 1.0-fold (0.02 log units) above; the range from low to high includes it.
By their numbers in this assay, from the lowest: compounds 3, 1 and 2 (each within the scatter of the next).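

In this assay, the (4-nitrophenyl)carbamoyl group on the amine nitrogen gives a 1.1-fold lower number from compound 2 to compound 3 (0.03 log units; within the scatter), and nitro in place of methoxy on an aromatic carbon gives a 1.1-fold lower number from compound 1 to compound 3 (0.03 log units; within the scatter). This position has thus now taken a change of the substituent on the aromatic ring, as well as the earlier change at the carbonyl, without any step beyond the scatter. Nothing measured bears on this result. From the compounds shown here alone, whether an amine or a carboxylic acid in place of nitro, or a longer chain on the amine nitrogen, would give a step beyond the scatter remains open.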